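The compounds below may be only part of what the source reports. "The series", "measured", "known", "first", "only" and "open" are said of these compounds alone.

Compound 1, `O=C(O)Cc1sc(C(c2ccc(F)cc2)c2ccc(F)cc2)nc1-c1cc(F)cc(F)c1`, gives 35 nM in an in vitro assay on HEK385-7 cells for displacement of a labelled ligand from prostaglandin D2 receptor 2 (Homo sapiens); on this read-out higher numbers stand for weaker inhibition and lower numbers for stronger inhibition.
Compound 2, `O=C(O)Cc1sc(C(c2ccc(F)cc2)c2ccc(F)cc2)nc1-c1cn[nH]c1`, gives 16 nM.
Compound 3, `O=C(O)Cc1sc(C(c2ccc(F)cc2)c2ccc(F)cc2)nc1-c1cc(F)nc(F)c1`, is not yet measured.

Compound 2 has the lower of the two numbers. For the measured compounds named here, the only measured step is a 2.2-fold lower number from compound 1 to compound 2 (0.34 log units; beyond the scatter), a modest change. Compound 3 differs from compound 2 by 2,6-difluoropyridin-4-yl in place of 1H-pyrazol-4-yl on an aromatic carbon. Going by the values given here, the entering group is closer in kind to the group of compound 1 than to that of compound 2, so this one step is the sole guide, and a step of about its size back in the opposite direction is expected, namely a 1.9-fold higher number from compound 2 to compound 3 (0.27 log units; within the scatter). Compound 3 is therefore estimated at 30 nM, within 12 nM to 80 nM.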

Compound 3, half-maximal inhibitory concentration: 5.4 nM
Compound 3: middle estimate off by 5.6-fold (0.74 log units), on the high side, outside the stated range (below it).
By their numbers in this assay, from the lowest: compound 3; then compound 2; then compound 1.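

The 2,6-difluoropyridin-4-yl group has no hydrogen-bond donor, yet it gives a 3.0-fold lower number from compound 2 to compound 3 (0.47 log units; beyond the scatter), so a donor at this position is not needed for a low number. Putting it in place of 3,5-difluorophenyl gives a 6.5-fold lower number from compound 1 to compound 3 (0.81 log units; beyond the scatter), so six-membered rings here fall on both sides of the five-membered 1H-pyrazol-4-yl, and ring size alone does not set the order. Nothing available explains these differences.

From the compounds shown here alone, it remains open whether the ring nitrogen or the fluorines matter more. Plain pyridin-4-yl, or a pyridine ring carrying chlorine in place of fluorine, would help separate them.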